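The source may report more compounds than this note shows. Statements on the series, on what has been measured and on what is new or still open speak of the compounds shown alone.

Measured so far in a functional assay on B16 cells (Mus musculus) for cytotoxicity, read by MTT assay, with a stated time of 48 h; a lower number here means a stronger inhibitor, a higher number a weaker inhibitor:
- compound 1, `O=C(Cn1cc(C(=O)NCc2cn(Cc3ccccc3)nn2)nn1)OCc1ccccc1`: 22400 nM
- compound 3, `CCOC(=O)Cn1cc(C(=O)Nc2cccc(-c3cn(Cc4ccccc4)nn3)c2)nn1`: 20400 nM
- compound 2, `CCOC(=O)Cn1cc(CNC(=O)c2cn(CC(=O)OCc3ccccc3)nn2)nn1`: a limit of the assay, > 100000 nM

Compound 1 and compound 3 sit within the scatter of each other in this assay, and their cores share the same atoms joined differently; the difference between the two cores is not broken down here. Compound 2 reports only a limit, (the limit of > 100000 nM in this assay, at which 1 of the 3 values shown sits). Among the compounds with values here, the one change measured in full is ethoxycarbonyl in place of phenyl on a saturated chain carbon bound to an aromatic nitrogen, which gives an at least 4.4-fold higher number from compound 1 to compound 2 (0.64 log units; beyond the scatter).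

Compound 4, `CCOC(=O)Cn1cc(C(=O)Nc2cccc(-c3cn(CC(=O)OCC)nn3)c2)nn1`, is not yet measured. It carries the same change relative to compound 3, namely (ethoxycarbonyl in place of phenyl on a saturated chain carbon bound to an aromatic nitrogen), made at the same place as in the step from compound 1 to compound 2. On that basis the step of a 4.9-fold higher number from compound 3 to compound 4 (0.69 log units; beyond the scatter) is expected, a weakening of at least the size seen in an at least 4.4-fold higher number from compound 1 to compound 2 (0.64 log units; beyond the scatter). Compound 3 starts at 20400 nM. A step of that size is expected to carry compound 4 close to the top of the range this assay reads. Compound 4 is therefore estimated at 100000 nM, most likely between 45000 nM and 300000 nM.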

Compound 4, half-maximal inhibitory concentration: > 100000 nM
Compound 4 was reported as a limit; the forecaster's own chance of this, stated with the estimate: 55%; the middle value lies on the limit itself.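

In this assay, ethoxycarbonyl in place of phenyl on a saturated chain carbon bound to an aromatic nitrogen gives an at least 4.9-fold higher number from compound 3 to compound 4 (0.69 log units; beyond the scatter), so the number rises beyond the scatter on a second core, and the change carries over in direction: the same change on two cores in this assay, an at least 4.4-fold higher number (0.64 log units; beyond the scatter) from compound 1 to compound 2 and an at least 4.9-fold higher number (0.69 log units; beyond the scatter) from compound 3 to compound 4; the limit leaves it open whether they differ. Compound 4 gives > 100000 nM, which is a limit of the assay and not a number, and compound 2 also stands at a limit: the limit of > 100000 nM in this assay, at which 2 of the 4 values shown sit. The two steps therefore show only that the weakening appears on both cores; they do not give its true size on either core, and they do not show whether the core alters that size.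

The compounds shown leave open how a carboxylic acid or an amine would read at this place in this assay. They also leave open whether a cyclohexyl group or a longer alkyl chain there would read like phenyl or like ethoxycarbonyl.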